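A second methyl on the anilino ring of compound 1

The source may report more compounds than this note shows. Statements on the series, on what has been measured and on what is new or still open speak of the compounds shown alone.

Among the measured compounds shown here, compound 1 `COc1ccc(Nc2nc(Cl)cn([C@H](C)C3CC3)c2=O)c(C)n1` is one of two compounds measured in an assay on frontal cortex for displacement of a labelled ligand from corticotropin-releasing factor receptor 1 (Rattus norvegicus) (a lower number here means a stronger inhibitor, a higher number a weaker inhibitor), where compound 1 gives 11 nM. For the measured compounds named here, its only measured neighbour is compound 2 `COc1ccc(Nc2nc(Cl)cn([C@H](C)C3CC3)c2=O)c(OC)n1`, in which a methoxy replaces the methyl on an aromatic carbon; in this assay compound 2 gives 17 nM, and the step of a 1.5-fold higher number from compound 1 to compound 2 (0.19 log units; within the scatter) stays within the scatter. Compound 1 therefore holds the lower of the two numbers, but the two are not distinguishable.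

Compound 3 `COc1cc(C)c(Nc2nc(Cl)cn([C@H](C)C3CC3)c2=O)c(C)n1` differs from compound 1 by methyl in place of hydrogen on an aromatic carbon. Going by the values given here, no measured step touches this position: the single step that exists, from compound 1 to compound 2, concerns a different aromatic carbon and was itself within the scatter. The data thus give no direction for the new methyl, and one small group on an aromatic carbon of this ring already changed little. The expected step is no change at the digits printed from compound 1 to compound 3 (within the scatter), which is none beyond the scatter. For compound 3 the estimate in this assay is 11 nM, with a range from 4 nM to 30 nM.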

Compound 3, half-maximal inhibitory concentration: 12 nM
Compound 3: the middle estimate sits 1.1-fold (0.04 log units) below what was measured; the measured number falls inside the stated range.
By their numbers in this assay, from the lowest: compounds 1, 3 and 2 (each within the scatter of the next).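

In this assay, methyl in place of hydrogen on the aromatic carbon ortho to a large group and opposite the ring nitrogen gives a 1.1-fold higher number from compound 1 to compound 3 (0.04 log units; within the scatter) and so stays within the scatter, which gives this position, untouched by the earlier step, its first reading. Alongside a 1.5-fold higher number from compound 1 to compound 2 (0.19 log units; within the scatter) at a different aromatic carbon of the same ring, this makes two single small-group exchanges on this ring, and neither moves the number beyond the scatter. No accompanying measurement shows why the number holds at this position.

The compounds shown leave open whether a group of another kind on this same carbon, such as an amine, a carboxylic acid or a longer chain, would move the number beyond the scatter, as a single methyl says little about anything larger or charged. They also leave open whether the new methyl would read the same with the methoxy of compound 2 in place of the other methyl, and whether any of this holds outside this assay.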